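Sulfonyl in Place of Carbamoyl on the Ring Nitrogen

The compounds below may be only part of what the source reports. "The series", "measured", "known", "first", "only" and "open" are said of these compounds alone.

compound 1, `C=CCNC(=O)n1c(-c2ccc(OC)cc2)cc(=O)c2c(OC)cc(OC)cc21`: 12000 nM
compound 2, `COc1ccc(-c2cc(=O)c3c(OC)cc(OC)cc3n2S(=O)(=O)c2cc(Cl)cc(Cl)c2O)cc1`: > 37900 nM

Within the data shown here, in a functional assay on KOPN-8 cells (Homo sapiens) for antiproliferative activity, with a stated time of 72 h (on this read-out higher numbers stand for an effect only at larger amounts of compound and lower numbers for an effect already at smaller amounts), compound 1 gives 12000 nM and holds the only number among the measured values. Compound 2 reaches only a limit in this assay, namely (the limit of > 37900 nM in this assay, at which 1 of the 2 values shown sits). Compound 3 `COc1ccc(-c2cc(=O)c3c(OC)cc(OC)cc3n2S(=O)(=O)c2ccc(Br)s2)cc1` is not yet measured; it differs from compound 1 by (5-bromothiophen-2-yl)sulfonyl in place of allylcarbamoyl on an aromatic nitrogen. Among the measured compounds shown here, no step between measured compounds is available, so the size of the change can only be expected. The step of a 2.5-fold higher number from compound 1 to compound 3 (0.40 log units; beyond the scatter) is expected to run toward weaker effect, beyond the scatter. Compound 3 is estimated at 30000 nM, between 10000 nM and 80000 nM, with a real chance that only a limit is reported.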

Compound 3, half-maximal effective concentration: > 48200 nM
Compound 3: no number, only a limit; the forecaster's own chance of this, stated with the estimate: 50%; middle value at least 1.6-fold (0.20 log units) away from the limit.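

In this assay, among these compounds, (5-bromothiophen-2-yl)sulfonyl in place of allylcarbamoyl on the aromatic nitrogen gives an at least 4.0-fold higher number from compound 1 to compound 3 (0.60 log units; beyond the scatter), the first readable step at this position and one toward weaker effect. Compound 3 reaches only a limit, not a number: the limit of > 48200 nM in this assay, at which 1 of the 3 values shown sits. Among the three compounds, both sulfonyl compounds end at limits, and only the allylcarbamoyl compound 1 gives a number.

The step between the two sulfonyl compounds cannot be read, so the groups on the sulfonyl sulfur cannot be ranked. From the compounds shown here alone, it remains open whether a methyl on that sulfur, or a carbamoyl carrying a longer chain or an amine, would give a number.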